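A few compounds are considered here, and "the series" means these few. Any claim that something is new, unique, unknown or untested is made for them only; others in the source may bear on it.

Measured so far in a functional assay on CHO-K1 cells for antagonist activity at transient receptor potential cation channel subfamily V member 1 (Homo sapiens), read by FLIPR; on this read-out higher numbers stand for weaker inhibition and lower numbers for stronger inhibition:
compound 1 `CC(C(=O)NCc1ccc(C(F)(F)F)nc1NC1CCCCC1)c1ccc(NS(C)(=O)=O)c(F)c1` — 20.4 nM
compound 2 `CC(C(=O)NCc1ccc(C(F)(F)F)nc1NCc1ccccc1)c1ccc(NS(C)(=O)=O)c(F)c1` — 15.8 nM
compound 3 `CC(C(=O)NCc1ccc(C(F)(F)F)nc1N1CCC(C)(C)CC1)c1ccc(NS(C)(=O)=O)c(F)c1` — 0.3 nM

Compound 3 gives the lowest number of the three. Its steps to the others are both large: a 68-fold lower number from compound 1 to compound 3 (1.83 log units; beyond the scatter) and a 53-fold lower number from compound 2 to compound 3 (1.72 log units; beyond the scatter), each beyond the scatter, so compound 3 is the strongest inhibitor in this set. Between compound 1 and compound 2 the difference is only a 1.3-fold lower number from compound 1 to compound 2 (0.11 log units; within the scatter), within the scatter.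

Compound 4 `CC(C(=O)NCc1ccc(C(F)(F)F)nc1N1CCN(C2CCCCC2)CC1)c1ccc(NS(C)(=O)=O)c(F)c1` changes the group on the aromatic carbon next to the ring nitrogen: 4-cyclohexylpiperazin-1-yl in place of 4,4-dimethylpiperidin-1-yl on an aromatic carbon.

Among the measured compounds shown here, no measured step covers this exact change. The two large steps into compound 3 show that a ring attached through its own nitrogen, in place of a cyclohexylamino or benzylamino group, gives the big gain. For the measured compounds named here, compound 4 keeps that kind of attachment but carries a second nitrogen bearing cyclohexyl, which no measured pair tests directly. A modest loss relative to compound 3 is expected, with wide uncertainty, as a 5.0-fold higher number from compound 3 to compound 4 (0.70 log units; beyond the scatter).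

Compound 4 is estimated in this assay at 1.5 nM, within 0.3 nM to 8 nM.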

Compound 4, inhibition constant: 21.6 nM
Beside the measured number, compound 4's estimate is 14-fold (1.16 log units) below it; the measured number lies above the stated range.
By their numbers in this assay, from the lowest: compound 3; then compounds 2, 1 and 4 (each within the scatter of the next).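

Attachment through a ring nitrogen does not by itself hold the low number at this position: in this assay the 4-cyclohexylpiperazin-1-yl group gives a 72-fold higher number from compound 3 to compound 4 (1.86 log units; beyond the scatter) against 4,4-dimethylpiperidin-1-yl. The same group stands level with the cyclohexylamino and benzylamino groups, with a 1.1-fold higher number from compound 1 to compound 4 (0.02 log units; within the scatter) and a 1.4-fold higher number from compound 2 to compound 4 (0.14 log units; within the scatter) both within the scatter, so among these four compounds only the 4,4-dimethylpiperidin-1-yl group of compound 3 stands apart. Nothing at hand bears on the reason for this difference.

On these data alone, the separate contributions of the second ring nitrogen and of the cyclohexyl on it remain open. A 4-cyclohexylpiperidin-1-yl group or a 4-methylpiperazin-1-yl group on this aromatic carbon would separate the two.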